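From Primary Amide to Methyl Ester on the Aryl Amide

The compounds below may be only part of what the source reports. "The series", "measured", "known", "first", "only" and "open" are said of these compounds alone.

Compound 1, `C=C(CC)C(=O)c1ccc(OCC(=O)NCCO)c(Cl)c1Cl`, and compound 2, `C=C(CC)C(=O)c1ccc(OCC(=O)Nc2ccc(C(N)=O)cc2)c(Cl)c1Cl`, share one core and differ only in the group on an amide-type nitrogen. In a functional assay on CLL cells (Homo sapiens) for cytotoxicity, read by MTT assay, with a stated time of 48 h (a lower number here means that less compound is needed, a higher number that more compound is needed for the effect), compound 1 reaches > 25000 nM. That value of compound 1 is a limit of the assay, not a number: the limit of > 25000 nM in this assay, at which 1 of the 2 values shown sits. In this assay compound 2 gives 3700 nM. Among the compounds with values here, the step of an at least 6.7-fold lower number from compound 1 to compound 2 (0.82 log units; beyond the scatter) is the only measured step. Among the values shown, compound 2 holds the only true number. Compound 3, `C=C(CC)C(=O)c1ccc(OCC(=O)Nc2ccc(C(=O)OC)cc2)c(Cl)c1Cl`, carries a further change: methoxy in place of amino on a carbonyl carbon. Within the data shown here, the one measured step altered the group on the nitrogen, not the group on the carbonyl carbon of that ring, so it gives little guidance here. Without a closer precedent, a step within the usual scatter is expected, no change at the digits printed from compound 2 to compound 3 (within the scatter). Compound 3 is therefore estimated at 3700 nM, with a range from 1200 nM to 11000 nM.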

Compound 3, half-maximal effective concentration: 4100 nM
Estimate against measurement, compound 3: 1.1-fold (0.04 log units) below; low and high end bracket the measured number.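

In this assay, the swap of carbamoyl for methoxycarbonyl gives a 1.1-fold higher number from compound 2 to compound 3 (0.04 log units; within the scatter), so compound 2 and compound 3 cannot be told apart in this read-out. The earlier step changed the group on the amide-type nitrogen; this one shows that, on this carbonyl carbon, amino with its hydrogen-bond donor can give way to methoxy, which has no such donor, with no change beyond the scatter. Nothing measured here bears on why these two compounds read alike.

Still open, going by these compounds, is how a carboxylic acid, or a larger ester such as ethoxycarbonyl, would read on this same carbonyl carbon. A single pair also leaves open whether an amine such as methylamino in place of amino would read like compound 2 and compound 3.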